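Chain extension in 4-hydroxyphenyl ketones: toward compound 3

The compounds below may be only part of what the source reports. "The series", "measured", "known", "first", "only" and "open" are said of these compounds alone.

Measured so far in an assay on isolated protein for inhibition of 17-beta-hydroxysteroid dehydrogenase type 3 (Homo sapiens); a higher number here means a weaker inhibitor, a lower number a stronger inhibitor:
Compound 1 `CCCCCC(=O)c1ccc(O)cc1` — 18000 nM
Compound 2 `CCCCCCC(=O)c1ccc(O)cc1` — 7840 nM

Compound 2 has the lowest of the two numbers seen; its nearest neighbour is compound 1, where the step of a 2.3-fold lower number from compound 1 to compound 2 (0.36 log units; beyond the scatter) is the only one recorded for the series.

Compound 3 `CCCCCCCCCC(=O)c1ccc(O)cc1` has not yet been measured. It differs from compound 2 by propyl in place of hydrogen on a saturated chain carbon, six bonds along the chain from a carbonyl carbon.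

Among the measured compounds shown here, the one step that bears on this change is the step from compound 1 to compound 2, where one more chain carbon brought a modest drop beyond the scatter, a 2.3-fold lower number from compound 1 to compound 2 (0.36 log units; beyond the scatter). For the measured compounds named here, the change to compound 3 adds three chain carbons in the same direction, so a larger drop in this assay is expected, though with only a single step behind it the size is uncertain.

For compound 3 the expected value is 2500 nM, with a range from 800 nM to 8000 nM. The expected step from compound 2 to compound 3 is therefore a 3.1-fold lower number from compound 2 to compound 3 (0.50 log units; beyond the scatter).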

Compound 3, half-maximal inhibitory concentration: 4970 nM
For compound 3 the middle estimate is 2.0-fold (0.30 log units) below the measured one, and the stated range covers the measured number.
By their numbers in this assay, from the lowest: compounds 3 and 2 (each within the scatter of the next); then compound 1.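

In this assay, propyl in place of hydrogen on a saturated chain carbon, six bonds along the chain from a carbonyl carbon, gives a 1.6-fold lower number from compound 2 to compound 3 (0.20 log units; within the scatter), so compound 2 and compound 3 cannot be told apart, unlike the earlier methyl change that gave a step beyond the scatter. Over the whole span the record reads a 3.6-fold lower number from compound 1 to compound 3 (0.56 log units; beyond the scatter), still a modest step, so the three further chain carbons of compound 3 do not extend the earlier trend in proportion, and the series so far looks more like a level stretch than a steady run along the chain. No data at hand bear on what lies behind this flattening.

On these data alone, whether a longer chain would stay level with compound 2 and compound 3 or leave that level in either direction remains open, since three chain lengths cannot define the shape of the trend. Also open, as far as these compounds go, is how the assay would respond to a chain carrying an amine or a carboxylic acid, or to a ring in place of the chain.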